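Benzyl thioether variation on a shared core

A few compounds are considered here, and "the series" means these few. Any claim that something is new, unique, unknown or untested is made for them only; others in the source may bear on it.

Measured compounds:
compound 1, `Cc1cc(Nc2cc(-c3ccccc3)[nH]n2)n2nc(SCc3ccc(F)cc3)nc2n1`: 4020 nM
compound 2, `Cc1cc(Nc2cc(-c3ccccc3)[nH]n2)n2nc(SCc3ccc([N+](=O)[O-])cc3)nc2n1`: 5060 nM
compound 3, `Cc1cc(Nc2cc(-c3ccccc3)[nH]n2)n2nc(SCc3cccc(Br)c3)nc2n1`: 5140 nM

All three share one core and differ only in the benzyl group on the sulfur. In a functional assay on MCF7 cells (Homo sapiens) for inhibition, read by MTT assay, with a stated time of 72 h (a lower number here means a stronger inhibitor, a higher number a weaker inhibitor), compound 1 gives the lowest of the three numbers, but the gaps are small: a 1.3-fold higher number from compound 1 to compound 2 (0.10 log units; within the scatter) and a 1.3-fold higher number from compound 1 to compound 3 (0.11 log units; within the scatter) both lie within the scatter, as does a 1.0-fold higher number from compound 2 to compound 3 (0.01 log units; within the scatter). No ordering among the three can be drawn from these values.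

Compound 4, `Cc1cc(Nc2cc(-c3ccccc3)[nH]n2)n2nc(SCc3ccc(C(F)(F)F)cc3)nc2n1`, keeps the core and the benzyl arrangement of compound 1 and changes the substituent on the benzyl ring: trifluoromethyl in place of fluoro on an aromatic carbon.

Within the data shown here, the step that bears most directly on this change is the one from compound 1 to compound 2, where a different group replaced the same fluoro at the same place; it was within the scatter. The steps to compound 3 move the substituent as well as change it, and were also within the scatter. Among the measured compounds shown here, nothing among the measured compounds indicates that a substituent swap on this benzyl ring moves the number beyond the scatter.

Compound 4 is therefore expected to give a number close to that of compound 1, a 1.1-fold higher number from compound 1 to compound 4 (0.05 log units; within the scatter), estimated at 4500 nM with a range of 2000 nM to 10000 nM.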

Compound 4, half-maximal inhibitory concentration: 4820 nM
For compound 4 the middle estimate is 1.1-fold (0.03 log units) below the measured one; the measured number falls inside the stated range.
By their numbers in this assay, from the lowest: compounds 1, 4, 2 and 3 (each within the scatter of the next).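

In this assay, trifluoromethyl enters with 4 heavy atoms where fluoro had 1 heavy atom, and the result is a 1.2-fold higher number from compound 1 to compound 4 (0.08 log units; within the scatter), so on this aromatic carbon the difference in heavy-atom count comes with no step beyond the scatter. The comparisons with the other two benzyl groups read the same way, with a 1.0-fold lower number from compound 2 to compound 4 (0.02 log units; within the scatter) for the replacement of nitro and a 1.1-fold lower number from compound 3 to compound 4 (0.03 log units; within the scatter) for the replacement of 3-bromophenyl by 4-(trifluoromethyl)phenyl, so all four benzyl thioethers now lie within the scatter of one another and no ordering among them can be drawn. No measurement at hand bears on why the number stays within the scatter across these benzyl groups.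

From the compounds shown here alone, whether this holds for substituents of another kind on the benzyl ring, such as an amine, a carboxylic acid or a longer alkyl chain, remains open. Also open, going by these compounds, is what happens when the change lies elsewhere, for example when the benzyl group on the sulfur gives way to a plain ethyl chain, or when the phenyl on the other side of the shared core carries a substituent.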